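The source may hold more compounds than are shown below. What is called first, only, known or untested is meant among the compounds shown, and "the series" means these compounds.

Working notes on cytotoxicity in the series.

The series is read in an ADME assay on Vero cells (Chlorocebus sabaeus) for cytotoxicity, with a stated time of 72 h; a lower number here means that less compound is tolerated, a higher number that more compound is tolerated. Compound 1 `CN1CCN(c2ccc(C(=O)/C=C/c3ccc(Cl)cc3)cc2)CC1` gives 102 ug/mL. Compound 2 `CCCCNc1ccc(C(=O)C2CC2c2ccc(Cl)cc2)cc1` gives 316 ug/mL. Compound 3 `O=C(c1ccc(N2CCN(c3cccc(Cl)c3Cl)CC2)cc1)C1CC1c1ccc(Cl)cc1` gives 383 ug/mL. On these three numbers compound 2 stands second highest; compound 3 is its nearest neighbour, within the scatter, while compound 1 is its furthest, with a gap beyond the scatter.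

Compound 4 `O=C(c1ccc(NCCO)cc1)C1CC1c1ccc(Cl)cc1` has not been measured in this assay. Set beside compound 2, the difference is hydroxy in place of ethyl on a saturated chain carbon, two bonds along the chain from a nitrogen on an aromatic ring. The change is confined to the chain on the amine; the core and the chlorophenyl cyclopropyl ketone part are untouched.

Among the compounds with values here, no measured pair in the set isolates this kind of change, so the expectation rests on compound 2 alone and on the narrow spread between compound 2 and compound 3. In this assay the step from compound 2 to compound 4 is expected to be small, a 1.1-fold higher number from compound 2 to compound 4 (0.04 log units; within the scatter), and not clearly beyond the scatter in either direction. Compound 4 is therefore estimated at 350 ug/mL, with a range from 170 ug/mL to 720 ug/mL.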

Compound 4, half-maximal cytotoxic concentration: 305 ug/mL
Estimate against measurement, compound 4: 1.1-fold (0.06 log units) above; the range from low to high includes it.
By their numbers in this assay, from the lowest: compound 1; then compounds 4, 2 and 3 (each within the scatter of the next).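

In this assay, within the data shown here, replacing ethyl with hydroxy on a saturated chain carbon, two bonds along the chain from a nitrogen on an aromatic ring, gives a 1.0-fold lower number from compound 2 to compound 4 (0.02 log units; within the scatter) and provides the first one-place step. At this position, butylamino and (2-hydroxyethyl)amino are therefore not told apart by this read-out, even though the change removes two carbons and brings in a hydrogen-bond donor and acceptor. No supporting measurement bears on why the step is this small.

This is a single step on a single chain, so it does not show whether the same holds for other chains on this amine. Still open, going by these compounds, are a carboxylic acid or a primary amine at the chain end, and a longer chain carrying the hydroxy group.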